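The compounds below may be only part of what the source reports. "The series", "measured", "known", "first", "only" and "open" are said of these compounds alone.

Measured so far in an ADME assay on BEAS-2B cells (Homo sapiens) for cytotoxicity, read by MTT assay, with a stated time of 72 h; a higher number here means a weaker inhibitor of growth, a lower number a stronger inhibitor of growth:

Compound 1, `Nc1nc([SeH])nc2ncccc12`: 87700 nM
Compound 2, `CCCCC[Se]c1nc(N)c2cccnc2n1`: 44900 nM
Compound 3, `Nc1nc([SeH])nc2ccccc12`: here the assay reports only a limit, > 100000 nM

Two cores occur in the set. Compound 2 arises from compound 1 by pentyl in place of hydrogen on a selenium, and the measured step was a 2.0-fold lower number from compound 1 to compound 2 (0.29 log units; within the scatter). The core of compound 3 differs from the core of compound 1, but the difference between the two cores is not broken down here. Compound 3 sits at the limit of > 100000 nM in this assay, at which 1 of the 3 values shown sits.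

Compound 4, `CCCCC[Se]c1nc(N)c2ccccc2n1`, is not yet measured in this assay. It stands to compound 3 as compound 2 stands to compound 1: the same change, (pentyl in place of hydrogen on a selenium), at the same place. Within the data shown here, the expected step is therefore an at least 1.4-fold lower number from compound 3 to compound 4 (0.15 log units; that floor lies within the scatter), resting on a 2.0-fold lower number from compound 1 to compound 2 (0.29 log units; within the scatter), which is the only measured instance of this change. The expected value for compound 4 is 70000 nM, estimated between 35000 nM and 150000 nM. A return of only a limit for compound 4 remains quite possible, as compound 3 itself sits at the limit of > 100000 nM in this assay, at which 1 of the 3 values shown sits.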

Compound 4, concentration for total growth inhibition: > 100000 nM
Compound 4 gave a limit, no number; the forecaster's own chance of this, stated with the estimate: 40%; middle value at least 1.4-fold (0.15 log units) away from the limit.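

Compound 3 and compound 4 each return only a limit in this assay, so the step between them cannot be read: the limit of > 100000 nM in this assay, at which 2 of the 4 values shown sit.

The compounds shown leave open what pentyl in place of hydrogen on a selenium does to the number in this assay on the core of compound 3, and how that would compare with a 2.0-fold lower number from compound 1 to compound 2 (0.29 log units; within the scatter).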